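A few compounds are considered here, and "the series" means these few. Any claim that something is new, unique, unknown or untested is made for them only; others in the source may bear on it.

Measured so far in a functional assay on CHOK cells for antagonist activity at growth hormone secretagogue receptor type 1 (Homo sapiens), read by calcium flux; a lower number here means a stronger inhibitor, a higher number a weaker inhibitor:
compound 1, `Nc1nc(N)c(-c2ccc(NCc3ccc([N+](=O)[O-])cc3)cc2)c(COCc2ccccc2)n1`, 5.8 nM
compound 2, `Nc1nc(N)c(-c2ccc(NCc3ccnc(Cl)c3)cc2)c(COCc2ccccc2)n1`, 3.6 nM
compound 3, `Nc1nc(N)c(-c2ccc(NCc3csc(Cl)c3)cc2)c(COCc2ccccc2)n1`, 170 nM

Compound 3 stands at the highest number of the three. Its nearest neighbour is compound 1, a 29-fold higher number from compound 1 to compound 3 (1.47 log units; beyond the scatter), and its furthest is compound 2, a 47-fold higher number from compound 2 to compound 3 (1.67 log units; beyond the scatter); both of these steps lie well beyond the scatter, so compound 3 is the weakest inhibitor among the measured compounds. Compound 1 and compound 2 lie within the scatter of each other, as a 1.6-fold lower number from compound 1 to compound 2 (0.21 log units; within the scatter) shows.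

Compound 4, `Nc1nc(N)c(-c2ccc(NCc3ccncc3)cc2)c(COCc2ccccc2)n1`, has not yet been measured. It differs from compound 3 in one place: pyridin-4-yl in place of 5-chlorothiophen-3-yl on a saturated chain carbon bound to a nitrogen on an aromatic ring. For the measured compounds named here, the steps that bear on this change are the two that lead into compound 3, both of which exchanged a six-membered ring for the 5-chlorothiophen-3-yl group and both of which raised the number by a large amount. Going by the values given here, compound 4 carries a pyridin-4-yl group, closest in kind to the 2-chloropyridin-4-yl of compound 2, though no measured step tells what removing the chlorine is worth. A large step downward is therefore expected, estimated at a 21-fold lower number from compound 3 to compound 4 (1.33 log units; beyond the scatter) in this assay. For compound 4 the expected value is 8 nM, with a range from 2 nM to 40 nM.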

Compound 4, half-maximal inhibitory concentration: 86 nM
Estimate against measurement, compound 4: 11-fold (1.03 log units) below, outside the stated range (above it).
By their numbers in this assay, from the lowest: compounds 2 and 1 (each within the scatter of the next); then compounds 4 and 3 (each within the scatter of the next).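

In this assay, for the compounds shown here, pyridin-4-yl on a saturated chain carbon bound to a nitrogen on an aromatic ring does not separate from 5-chlorothiophen-3-yl, with a 2.0-fold lower number from compound 3 to compound 4 (0.30 log units; within the scatter) as the step, so a six-membered aromatic ring at this place does not by itself give the low numbers of the earlier compounds. The chloro on the pyridine ring now has a measured worth: hydrogen in place of chloro on an aromatic carbon gives a 24-fold higher number from compound 2 to compound 4 (1.38 log units; beyond the scatter) as a large step. The same holds against the 4-nitrophenyl group, with a 15-fold higher number from compound 1 to compound 4 (1.17 log units; beyond the scatter) at this place, so among these compounds the low numbers go with a six-membered aromatic ring that bears a further group, while compound 3 shows that a chloro on a five-membered ring does not share them.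

The compounds shown leave open whether a methyl, a methoxy or a fluorine in the chloro's stead on the pyridine ring would keep the low number, and what a plain phenyl or a thiophen-3-yl without its chlorine would give. Nothing measured here speaks to what lies behind these steps.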